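Widening a small group on the shared core

The source may hold more compounds than are shown below. What is called first, only, known or untested is meant among the compounds shown, and "the series" means these compounds.

Values in an ADME assay for permeability, using PAMPA, at pH 4; on this read-out lower numbers stand for lower permeability and higher numbers for higher permeability:
Compound 1 `COc1cc2[nH]c(C)c(C3CCCCC3)c(=O)c2cc1Cl`: 1240 10^-6 cm/s
Compound 2 `COc1cc2[nH]c(C)c(C)c(=O)c2cc1Cl`: 37 10^-6 cm/s

Of these two numbers, the lower belongs to compound 2, at 37 10^-6 cm/s. Compound 1 gives 1240 10^-6 cm/s, and the gap between the two lies well beyond the scatter. Compound 3 `COc1cc2[nH]c(C)c(C(C)C)c(=O)c2cc1Cl` has not yet been measured. It differs from compound 2 by isopropyl in place of methyl on an aromatic carbon, which is isopropyl in place of methyl on an aromatic carbon.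

Among the measured compounds shown here, one measured step bears on this change, since it concerns the same place on the core. This is a 34-fold lower number from compound 1 to compound 2 (1.53 log units; beyond the scatter), a large step beyond the scatter, with methyl in place of cyclohexyl on an aromatic carbon. Isopropyl falls between cyclohexyl and methyl as a substituent, but it has no ring, and this single pair establishes no trend. A rise in this assay is therefore expected, smaller than the measured step, though probably still beyond the scatter. The expected change is a 4.9-fold higher number from compound 2 to compound 3 (0.69 log units; beyond the scatter). For compound 3 the estimated value is 180 10^-6 cm/s, with an expected range from 70 10^-6 cm/s to 500 10^-6 cm/s.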

Compound 3, apparent permeability: 281 10^-6 cm/s
For compound 3 the middle estimate is 1.6-fold (0.19 log units) below the measured one; low and high end bracket the measured number.
By their numbers in this assay, from the lowest: compound 2; then compound 3; then compound 1.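

In this assay this position now carries three groups, and the numbers rise in the order methyl, isopropyl, cyclohexyl, with none of the three compounds going against that order: a 7.6-fold higher number from compound 2 to compound 3 (0.88 log units; beyond the scatter), and a 4.4-fold lower number from compound 1 to compound 3 (0.64 log units; beyond the scatter). The earlier pair could show only the two ends of this series, whereas the new compound places a point inside it: isopropyl, which has no ring, already gives a rise beyond the scatter over methyl, so at this position a ring is not needed for such a rise, while cyclohexyl still stands beyond the scatter above isopropyl. Nothing at hand gives a measured reason for these differences at this position.

From the compounds shown here alone, three compounds make only a short series, so it remains open whether the order would hold for ethyl, tert-butyl, cyclopropyl or a longer chain such as n-hexyl, or whether the numbers would keep rising with larger groups or level off. Also open, going by these compounds, is what an amine or a carboxylic acid would do at this place, and whether the same steps would appear on any core other than the shared one.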